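The compounds below may be only part of what the source reports. "The series", "measured", "known", "first", "only" and "open" are said of these compounds alone.

Working notes on the series. The assay is a functional assay on MDA-MB-231 cells (Homo sapiens) for cytotoxicity, read by sulforhodamine B assay, with a stated time of 72 h; on this read-out higher numbers stand for weaker inhibition of growth and lower numbers for stronger inhibition of growth. Compound 1 `O=C(Nc1ccccc1C(F)(F)F)C1CCc2ccccc2N1C(=O)c1cccc(Cl)c1` gives 288 nM. Going by the values given here, compound 2 `O=C(Nc1ccccc1O)C1CCc2ccccc2N1C(=O)c1ccccc1` gives 4210 nM, the higher of the two numbers known so far, and the gap to compound 1 is beyond the scatter; no single-change step links the two, so the two values are only placed side by side. Compound 3 `O=C(Nc1ccccc1O)C1CCc2ccccc2N1C(=O)c1cccc(Cl)c1` differs from compound 2 by chloro in place of hydrogen on an aromatic carbon. Among the compounds with values here, no measured step of this kind exists here. A modest downward move from compound 2 to compound 3, a 2.1-fold lower number from compound 2 to compound 3 (0.32 log units; beyond the scatter), is expected, at the edge of the scatter. For compound 3 the estimate is 2000 nM, between 600 nM and 7000 nM.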

Compound 3, concentration for 50% growth inhibition: 10600 nM
The estimate for compound 3 lay 5.3-fold (0.72 log units) below the measured number; the whole stated range lies below it.
By their numbers in this assay, from the lowest: compound 1; then compound 2; then compound 3.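

Chloro in place of hydrogen on this benzoyl ring does not lower the number with hydroxy on the other aromatic ring: the change gives a 2.5-fold higher number from compound 2 to compound 3 (0.40 log units; beyond the scatter), a modest rise. With the 3-chlorophenyl held fixed, hydroxy in place of trifluoromethyl is by far the larger change, giving a 37-fold higher number from compound 1 to compound 3 (1.57 log units; beyond the scatter). The compounds offer no measurement that accounts for either step. As far as these compounds go, it remains open whether chloro acts the same way alongside trifluoromethyl, and how an amine or a carboxylic acid would read in place of hydroxy.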